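A few compounds are considered here, and "the series" means these few. Any claim that something is new, unique, unknown or untested is made for them only; others in the source may bear on it.

Of the compounds shown here, three have been measured in a functional assay on HeLa cells (Homo sapiens) for inhibition, read by sulforhodamine B assay, with a stated time of 48 h; on this read-out lower numbers stand for stronger inhibition of growth and higher numbers for weaker inhibition of growth: compound 1 `COC(=O)[C@@]1(C)CCC=C2[C@@H]1CC[C@@H](C)[C@]2(C)Cc1c[nH]c2c(Br)cccc12` gives 13000 nM, compound 2 `COC(=O)[C@@]1(C)CCC=C2[C@@H]1CC[C@@H](C)[C@]2(C)Cc1c[nH]c2c(Cl)cccc12` gives 14000 nM, and compound 3 `COC(=O)[C@@]1(C)CCC=C2[C@@H]1CC[C@@H](C)[C@]2(C)Cc1c(C)[nH]c2ccc(Br)cc12` gives 11000 nM. Compound 4 `COC(=O)[C@@]1(C)CCC=C2[C@@H]1CC[C@@H](C)[C@]2(C)Cc1c(C)[nH]c2ccc(Cl)cc12` has not yet been measured.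

Compound 1 and compound 2 differ in one place, (chloro in place of bromo on an aromatic carbon), and this gave a 1.1-fold higher number from compound 1 to compound 2 (0.03 log units; within the scatter). How the core of compound 3 differs from the core of compound 1 is not broken down here. Compound 4 differs from compound 3 by the same kind of change, (chloro in place of bromo on an aromatic carbon); what differs around the place is that the group sits meta to a fused ring and para to a fused ring, rather than ortho to a fused ring and meta to a fused ring. Because a 1.1-fold higher number from compound 1 to compound 2 (0.03 log units; within the scatter) was so small a step, the step of a 1.1-fold higher number from compound 3 to compound 4 (0.04 log units; within the scatter) is expected to be small as well. Compound 4 is therefore estimated to give 12000 nM in this assay, most likely between 6000 nM and 25000 nM.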

Compound 4, concentration for 50% growth inhibition: 12000 nM
For compound 4 middle estimate and measured number coincide at the digits printed; the range from low to high includes it.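

Putting chloro in place of bromo on an aromatic carbon gave a 1.1-fold higher number from compound 3 to compound 4 (0.04 log units; within the scatter) in this assay. Set beside the earlier case, the two steps agree: the same change on two cores in this assay, a 1.1-fold higher number (0.03 log units; within the scatter) from compound 1 to compound 2 and a 1.1-fold higher number (0.04 log units; within the scatter) from compound 3 to compound 4, 1.0-fold (0.01 log units) apart, within the scatter of two such steps

On these two cores, with the halogen at two different places, the change therefore carries over, and neither step rises above the scatter. This does not show that it would carry over to other cores or other assays, and such small steps cannot say what the halogen itself contributes.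

From the compounds shown here alone, all four compounds carry either bromo or chloro, so it remains open whether a halogen is needed at all. Going by these compounds, how the number would respond to a plain hydrogen, a methoxy group or an amine in its place is also open.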